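A few compounds are considered here, and "the series" means these few. Any claim that something is new, unique, unknown or untested is made for them only; others in the source may bear on it.

Measured so far:
- compound 1 `CNC(=O)OC1CCN(c2ccc(-c3ccccc3Cl)nn2)CC1`: 10 mg/kg
- compound 2 `CN(C)C(=O)OC1CCN(c2ccc(-c3ccccc3Cl)nn2)CC1`: 2 mg/kg

Among the measured compounds shown here, in a functional assay on the whole organism with Mus musculus as the target, in the maximal electroshock model (on this read-out higher numbers stand for an effect only at larger amounts of compound and lower numbers for an effect already at smaller amounts), compound 2 gives 2 mg/kg, the lower of the two numbers so far. For the measured compounds named here, the only measured step, a 5.0-fold lower number from compound 1 to compound 2 (0.70 log units; beyond the scatter), is a methyl in place of hydrogen on an amide-type nitrogen. The next compound, compound 3 `C/N=C(\S)OC1CCN(c2ccc(-c3ccccc3Cl)nn2)CC1`, alters this same part of the molecule: a group of 4 heavy atoms (2 carbon, 1 nitrogen, 1 sulfur; no ring) in place of a group of 5 heavy atoms (3 carbon, 1 nitrogen, 1 oxygen; no ring), on an oxygen on a saturated carbon. The entering group lacks the methyl gained in that step, so a partial return toward compound 1 at 10 mg/kg is expected. Going by the values given here, no measured step shows what the sulfur does, so the expectation remains loose. A moderate rise is expected, estimated as a 3.0-fold higher number from compound 2 to compound 3 (0.48 log units; beyond the scatter). Compound 3 is estimated at 6 mg/kg, with an expected range of 2 mg/kg to 20 mg/kg.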

Compound 3, dose for half-maximal effect: 35 mg/kg
Compound 3: middle estimate off by 5.8-fold (0.77 log units), on the low side, and the stated range ends below it.
By their numbers in this assay, from the lowest: compound 2; then compound 1; then compound 3.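

In this assay, the group on this oxygen proves sensitive to more than the methyl on the nitrogen: leaving dimethylcarbamoyl for the sulfur-bearing group gives an 18-fold higher number from compound 2 to compound 3 (1.24 log units; beyond the scatter). Even against the partner that lacks that methyl, the change gives a 3.5-fold higher number from compound 1 to compound 3 (0.54 log units; beyond the scatter), so the missing methyl alone does not cover the rise, and this sulfur-bearing group ranks behind both carbamoyl groups shown. Nothing measured here explains this loss.

The sulfur, the double bond to nitrogen and the added hydrogen-bond donor all enter together, so the compounds shown do not separate their contributions. On these data alone, it also stays open whether dimethylthiocarbamoyl or diethylcarbamoyl on the same oxygen would match compound 2 at 2 mg/kg.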